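The source may hold more compounds than are shown below. What is called first, only, known or untested is meant among the compounds shown, and "the series" means these compounds.

In a toxicity assay on RMS13 cells (Homo sapiens) for inhibition, with a stated time of 24 h (on this read-out higher numbers stand for weaker inhibition of growth and lower numbers for stronger inhibition of growth), compound 2 `CC1=C(C(=O)OCc2ccccc2)C(c2ccc(-c3ccccc3)cc2)NC(=S)N1CCCCCC(=O)O` gives 100000 nM, which is level with compound 1 `CC1=C(C(=O)OCc2ccccc2)C(c2ccc(-c3ccccc3C)cc2)NC(=O)N1CCCCCc1nnn[nH]1` at 100000 nM, the two together standing as the highest numbers of the three measured; the remaining compound 3 `CC1=C(C(=O)OCc2ccccc2)C(c2ccc(-c3ccccc3C)cc2)N(Cc2ccc(-c3nnn[nH]3)cc2)C(=S)N1` gives 62000 nM, and its gap to compound 2 lies within the usual scatter. Compound 4 `CC1=C(C(=O)OCc2ccccc2)C(c2ccc(-c3ccccc3)cc2)NC(=S)N1CCCCCc1nnn[nH]1` is not yet measured in this assay. It differs from compound 2 in one place: 1H-tetrazol-5-yl in place of carboxy on a saturated chain carbon, five bonds along the chain from an amide-type nitrogen in a ring. Within the data shown here, no pair of measured compounds differs by this change alone, so no measured step exists for it. Compound 1 carries the same chain ending in 1H-tetrazol-5-yl and reads 100000 nM in this assay, at the same level as compound 2, which gives no sign of a shift. For compound 4 the expected step in this assay is therefore no change at the digits printed from compound 2 to compound 4 (within the scatter), none beyond the scatter. Compound 4 is accordingly estimated to give about 100000 nM in this assay, within a range from 50000 nM to 200000 nM.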

Compound 4, concentration for 50% growth inhibition: 110000 nM
Beside the measured number, compound 4's estimate is 1.1-fold (0.04 log units) below it, and the stated range covers the measured number.
By their numbers in this assay, from the lowest: compounds 3, 1, 2 and 4 (each within the scatter of the next).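

In this assay, 1H-tetrazol-5-yl in place of carboxy on a saturated chain carbon, five bonds along the chain from an amide-type nitrogen in a ring, gives a 1.1-fold higher number from compound 2 to compound 4 (0.04 log units; within the scatter) and so leaves the read-out without a shift beyond the scatter. Among these compounds, until this result, no measured pair differed by this change alone, so this is the first direct reading of the exchange at this place, and it rests on this one pair. No supporting measurement bears on why the two end groups read alike here.

As far as these compounds go, whether a primary amine or a hydroxyl at the end of the chain would read differently remains open. From the compounds shown here alone, it is also open whether a shorter or longer chain carrying carboxy or 1H-tetrazol-5-yl would move the read-out beyond the scatter.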